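The source may hold more compounds than are shown below. What is called first, only, known or untested is meant among the compounds shown, and "the series" means these compounds.

In an ADME assay on cells (Hepatocyte, Mus musculus) for cytotoxicity, read by MTT assay, with a stated time of 24 h (a lower number here means that less compound is tolerated, a higher number that more compound is tolerated), compound 1 `Cc1ccc(-c2nn(-c3ccccc3)cc2-c2nc3ccccc3n2S(=O)(=O)c2ccccc2)cc1` gives 189000 nM, compound 2 `O=S(=O)(c1ccccc1)n1c(-c2cn(-c3ccccc3)nc2-c2ccc(F)cc2)nc2ccccc21` gives 231000 nM and compound 3 `O=S(=O)(c1ccccc1)n1c(-c2cn(-c3ccccc3)nc2-c2ccc(C(F)(F)F)cc2)nc2ccccc21` gives 186000 nM. Compound 3 thus stands within the scatter of both other compounds. Compound 4 `O=S(=O)(c1ccc(Br)cc1)n1c(-c2cn(-c3ccccc3)nc2-c2ccc(C(F)(F)F)cc2)nc2ccccc21` differs from compound 3 by one change: bromo in place of hydrogen on an aromatic carbon, turning phenylsulfonyl into (4-bromophenyl)sulfonyl. Within the data shown here, no measured step touches this group. The nearest evidence is the swaps made elsewhere on the molecule, and a 1.2-fold higher number from compound 1 to compound 2 (0.09 log units; within the scatter), a 1.0-fold lower number from compound 1 to compound 3 (0.01 log units; within the scatter) and a 1.2-fold lower number from compound 2 to compound 3 (0.09 log units; within the scatter) all stay within the scatter. On that limited evidence, no change beyond the scatter is expected in this assay, and the expected step is a 1.1-fold lower number from compound 3 to compound 4 (0.04 log units; within the scatter). For compound 4 the estimate is 170000 nM, with an expected range of 90000 nM to 280000 nM.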

Compound 4, half-maximal cytotoxic concentration: 167000 nM
Estimate against measurement, compound 4: 1.0-fold (0.01 log units) above, within the range that was stated.
By their numbers in this assay, from the lowest: compounds 4, 3, 1 and 2 (each within the scatter of the next).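

Among these compounds, the phenylsulfonyl ring had not been changed in the earlier compounds; here, bromo on an aromatic carbon para to a large group gives a 1.1-fold lower number from compound 3 to compound 4 (0.05 log units; within the scatter) in this assay. Turning phenylsulfonyl into (4-bromophenyl)sulfonyl therefore leaves the number within the scatter, so the earlier flat picture now extends to this second part of the molecule. Nothing available explains this result. From the compounds shown here alone, what an amine, a carboxylic acid or a longer chain would do at this place in this assay remains open. Also open, going by these compounds, is whether bromo would behave alike elsewhere on this ring.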